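A few compounds are considered here, and "the series" means these few. Any claim that something is new, unique, unknown or untested is made for them only; others in the source may bear on it.

In an ADME assay on THP-1 cells (Homo sapiens) for cytotoxicity, read by flow cytometry and propidium iodide staining, with a stated time of 72 h (a higher number here means a weaker inhibitor, a lower number a stronger inhibitor), compound 2 (`CC(=O)Nc1ccc2oc(-c3cccc(F)c3)cc(=O)c2c1`) gives > 125000 nM, which is a limit and not a number. Compound 1 (`CC(=O)Nc1ccc2oc(-c3ccccc3F)cc(=O)c2c1`) gives > 125000 nM, also a limit. Compound 3 (`Nc1ccc2oc(-c3cccc(F)c3)cc(=O)c2c1`) gives > 125000 nM, again a limit. Among the compounds with values here, compound 2 therefore has no exact position, and the series so far stands at the limit of > 125000 nM in this assay, at which 3 of the 3 values shown sit.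

Compound 4 (`CC(=O)Nc1ccc2oc(-c3cccc(F)c3)c(O)c(=O)c2c1`) departs from compound 2 by one change: hydroxy in place of hydrogen on an aromatic carbon. Within the data shown here, two measured steps touch compound 2, namely a step that the two limits leave unreadable from compound 1 to compound 2 and a step that the two limits leave unreadable from compound 2 to compound 3. Neither has a size that can be read, and neither alters the carbon that takes the new hydroxy. They give no scale for this change, so no step beyond the scatter is expected in this assay, in either direction. The expected step is a number no higher from compound 2 to compound 4 (the limit leaves the size open). Compound 4 is estimated at 125000 nM, with an expected range from 60000 nM to 250000 nM.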

Compound 4, half-maximal inhibitory concentration: 36000 nM
Beside the measured number, compound 4's estimate is 3.5-fold (0.54 log units) above it; measured number outside the range, below it.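

In this assay, within the data shown here, hydroxy in place of hydrogen on the aromatic carbon ortho to a 3-fluorophenyl group gives an at least 3.4-fold lower number from compound 2 to compound 4 (0.54 log units; beyond the scatter), the first change whose effect exceeds the scatter. The earlier steps shown here, among compound 1, compound 2 and compound 3, cannot be read, and this step too has only a lower bound on its size, since the value for compound 2 is a limit. Compound 4 is the only compound shown with a number and not a limit: the limit of > 125000 nM in this assay, at which 3 of the 4 values shown sit.

As far as these compounds go, whether hydroxy at this carbon would give a similar step with the 2-fluorophenyl group of compound 1, or without the acetyl group as in compound 3, remains open. So does whether a methoxy group or an amine at the same carbon would lower the number as well.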